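The source may hold more compounds than are shown below. What is called first, only, known or untested is meant among the compounds shown, and "the series" means these compounds.

Compound 1 `N#CCCSC(=S)NCc1cccnc1` gives 1030 nM in a functional assay on Bel-7402 cells (Homo sapiens) for cytotoxicity, read by resazurin assay, with a stated time of 72 h; a higher number here means a weaker inhibitor, a lower number a stronger inhibitor.
Compound 2 `O=C(O)CCSC(=S)NCc1cccnc1` gives 7420 nM in this assay.
Compound 3 `Fc1ccccc1-c1nnc(CCSC(=S)NCc2cccnc2)o1` gives 5540 nM in this assay.

Among these three, compound 3 stands second highest in this assay; its number and that of compound 2 lie within the scatter of each other, while compound 1 sits beyond the scatter below it. Compound 4 `S=C(NCc1cccnc1)SCCc1nnc(-c2cc3ccccc3s2)o1` differs from compound 3 by 1-benzothiophen-2-yl in place of 2-fluorophenyl on an aromatic carbon. Among the measured compounds shown here, the single measured step, a 7.2-fold higher number from compound 1 to compound 2 (0.86 log units; beyond the scatter), concerns the end of the chain rather than the group on the five-membered ring, so no measured step bears directly on this change. The expectation is therefore a step of no more than the scatter in this assay, a 1.2-fold lower number from compound 3 to compound 4 (0.09 log units; within the scatter). Compound 4 is estimated at 4500 nM, with a range from 1500 nM to 13000 nM.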

Compound 4, half-maximal inhibitory concentration: 6890 nM
The estimate for compound 4 lay 1.5-fold (0.19 log units) below the measured number; the measured number falls inside the stated range.
By their numbers in this assay, from the lowest: compound 1; then compounds 3, 4 and 2 (each within the scatter of the next).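

In this assay, among the compounds shown here, a 1.2-fold higher number from compound 3 to compound 4 (0.09 log units; within the scatter) gives the first reading at this aromatic carbon of the five-membered aromatic ring. Exchanging 2-fluorophenyl for 1-benzothiophen-2-yl, which brings a second aromatic ring and a sulfur, leaves the number within the scatter, so these two groups cannot be told apart here. No evidence is available that would explain this result. Left open is whether an amine at this carbon would move the number beyond the scatter, and whether a longer chain to the five-membered ring would do so.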